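Isobutyl to Tert-Butyl Ester Swap Repeated on Second Core

The source may report more compounds than this note shows. Statements on the series, on what has been measured and on what is new or still open speak of the compounds shown alone.

Compound 1, `CC1=C(C(=O)OCC(C)C)C(c2ccoc2)NC(=O)N1`, gives 16% in an assay on membranes from HeLa cells for displacement of a labelled ligand from adenosine receptor A3 (Homo sapiens), read by scintillation counting, with a stated time of 180 min, tested at 1 uM; on this read-out higher numbers stand for more inhibition at the one concentration tested (going by the name of the read-out) and lower numbers for less inhibition.
Compound 2, `CC1=C(C(=O)OC(C)(C)C)C(c2ccoc2)NC(=O)N1`, gives 2% in this assay.
Compound 3, `CC1=C(C(=O)OCC(C)C)C(c2cccs2)NC(=O)N1C`, gives 5% in this assay.

Compound 1 and compound 2 share a core and differ only in the ester: tert-butyl in place of isobutyl on an oxygen next to a carbonyl group. This change gave a number 14 percentage points lower from compound 1 to compound 2 (beyond the scatter), a modest drop that lies beyond the scatter.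

Compound 3 has a different core; the difference between the two cores is not broken down here. Compound 4, `CC1=C(C(=O)OC(C)(C)C)C(c2cccs2)NC(=O)N1C`, not yet measured, stands to compound 3 exactly as compound 2 stands to compound 1: tert-butyl in place of isobutyl on an oxygen next to a carbonyl group. The place of the change is the same in both pairs, so this is the same change on a second core.

Because compound 3 already gives 5%, and the earlier step of a number 14 percentage points lower from compound 1 to compound 2 (beyond the scatter) went downward, little room remains. Compound 4 is expected to show a number 3 percentage points lower from compound 3 to compound 4 (within the scatter), a shrunken version of that step. The estimate for compound 4 is 2%, most likely between -5% and 12%.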

Compound 4, a percentage reported as inhibition, at one concentration (the size of the read-out at that concentration, not a potency): 22%
The estimate for compound 4 lay 20 percentage points below the measured number; the measured number lies above the stated range.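

On the second core, tert-butyl in place of isobutyl on an oxygen next to a carbonyl group gave a number 17 percentage points higher from compound 3 to compound 4 (beyond the scatter) in this assay. Set beside the first core, the same change does not carry over, since the two steps run in opposite directions: the same change on two cores in this assay, a number 14 percentage points lower (beyond the scatter) from compound 1 to compound 2 and a number 17 percentage points higher (beyond the scatter) from compound 3 to compound 4, 31 percentage points apart, beyond the scatter of two such steps

So, in these two pairs, the outcome of this ester change depends on the core that carries it, but four compounds cannot show which feature of the cores is responsible, and these single-concentration readings describe inhibition at that concentration, not potency.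

Going by these compounds, it remains open whether the change would go up or down on a third core, and which of the differences between the two cores decides its direction. On these data alone, it is also open how other groups at this place, such as an ethyl ester, a benzyl ester or a carboxylic acid, would behave on each core.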